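Compound 4 Against Compound 3 In Liver-Cell Toxicity

The compounds below may be only part of what the source reports. "The series", "measured", "known", "first", "only" and "open" are said of these compounds alone.

Compound 3 `CCN(CC)c1ccc2cc(C(=O)c3ccc(N4CCN(C(=O)CN5CCN(Cc6ccc(/C=C/C(=O)OC)cc6)CC5)CC4)cc3)oc2c1` was tested in an ADME assay on L02 cells (Homo sapiens) for cytotoxicity, read by MTT assay, with a stated time of 48 h (on this read-out lower numbers stand for stronger inhibition and higher numbers for weaker inhibition), and gave only a limit of the assay, > 100000 nM. Two of the three values shown in this assay sit at that limit (the limit of > 100000 nM in this assay, at which 2 of the 3 values shown sit). Compound 1 `CCN(CC)c1ccc2cc(C(=O)c3ccc(N4CCN(C(=O)CN5CCN(C(=O)CCl)CC5)CC4)cc3)oc2c1` gives 20900 nM in this assay. Compound 2 `CCN(CC)c1ccc2cc(C(=O)c3ccc(N4CCN(C(=O)CN5CCN(S(=O)(=O)C6CC6)CC5)CC4)cc3)oc2c1` gives a limit, > 100000 nM. Going by the values given here, the one measured step, an at least 4.7-fold higher number from compound 1 to compound 2 (0.67 log units; beyond the scatter), alters the amine nitrogen in a ring and not the aromatic carbon changed here. Compound 4 `CCN(CC)c1ccc2cc(C(=O)c3ccc(N4CCN(C(=O)CN5CCN(Cc6ccc(C(F)(F)F)cc6)CC5)CC4)cc3)oc2c1` differs from compound 3 by trifluoromethyl in place of 2-(methoxycarbonyl)ethenyl on an aromatic carbon. Among the compounds with values here, no measured step bears on this change, so the expectation rests on where compound 3 stands. Compound 4 is therefore expected to remain at the limit, with a number no higher from compound 3 to compound 4 (the limit leaves the size open) meaning no change beyond the scatter. The estimate for compound 4 is 100000 nM, within 40000 nM to 300000 nM.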

Compound 4, half-maximal inhibitory concentration: 6540 nM
Beside the measured number, compound 4's estimate is 15-fold (1.18 log units) above it; the measured number lies below the stated range.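

In this assay the group on this aromatic carbon turns out to matter, with an at least 15-fold lower number from compound 3 to compound 4 (1.18 log units; beyond the scatter), so a benzyl group on the ring nitrogen does not by itself hold a compound at the limit. The other two steps set the 4-(trifluoromethyl)benzyl group against the remaining groups on that nitrogen, with a 3.2-fold lower number from compound 1 to compound 4 (0.50 log units; beyond the scatter) and an at least 15-fold lower number from compound 2 to compound 4 (1.18 log units; beyond the scatter). Compound 2 and compound 3 each stand only at a limit of the assay, which leaves the full size of their steps open: the limit of > 100000 nM in this assay, at which 2 of the 4 values shown sit.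

The compounds shown leave open whether the step follows the loss of 2-(methoxycarbonyl)ethenyl or the arrival of trifluoromethyl. They also leave open how a carboxylic acid, a nitrile or a chlorine on this aromatic carbon would read.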